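The source may hold more compounds than are shown below. What is called first, only, known or untested is meant among the compounds shown, and "the series" means these compounds.

In a functional assay on A2780 cells (Homo sapiens) for antiproliferative activity, read by MTT assay, with a stated time of 72 h (a higher number here means a weaker inhibitor, a lower number a stronger inhibitor), compound 1 (`O=C(/C=C/c1ccc(CONC(=O)Nc2ccccc2)cc1)NO`) gives 112000 nM while compound 2 (`O=C(/C=C/c1ccc(CONC(=O)c2ccccc2)cc1)NO`) gives 2080 nM and so holds the lower of the two numbers. Compound 3 (`Cc1cc(C)cc(C(=O)NOCc2ccc(/C=C/C(=O)NO)cc2)c1`) differs from compound 2 in one place, with 3,5-dimethylphenyl in place of phenyl on a carbonyl carbon. Among the compounds with values here, the only measured step at that carbonyl carbon, a 54-fold lower number from compound 1 to compound 2 (1.73 log units; beyond the scatter) with phenyl in place of anilino, was large, but it removed anilino, whereas this change keeps an aromatic ring there. The expected step is only a 1.2-fold lower number from compound 2 to compound 3 (0.06 log units; within the scatter) and none beyond the scatter is expected in this assay here. Compound 3 is estimated at 1800 nM (range 600 nM to 6000 nM).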

Compound 3, half-maximal inhibitory concentration: 2330 nM
For compound 3 the middle estimate is 1.3-fold (0.11 log units) below the measured one; measured number inside the range.
By their numbers in this assay, from the lowest: compounds 2 and 3 (each within the scatter of the next); then compound 1.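

In this assay the step to 3,5-dimethylphenyl on the carbonyl carbon is a 1.1-fold higher number from compound 2 to compound 3 (0.05 log units; within the scatter), so at this position the two added methyl groups leave the number within the scatter of the phenyl compound. The large gap from the anilino compound also holds with this substituted ring, as a 48-fold lower number from compound 1 to compound 3 (1.68 log units; beyond the scatter) shows. No evidence is available to explain either step. The compounds shown leave open whether a saturated cyclohexyl ring, or a phenyl carrying a methoxy group, a chlorine or an amine, would stay level with compound 2 and compound 3 or move toward compound 1.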